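Nitro in place of amino on a benzimidazole-linked aryl ring

The compounds below may be only part of what the source reports. "The series", "measured", "known", "first", "only" and "open" are said of these compounds alone.

Measured so far:
compound 1, `COc1ccc(-c2nc3cc(Cl)c(Cl)cc3[nH]2)c(N)c1`, 3000 nM
compound 2, `Fc1cccc(F)c1-c1nc2cc(C(F)(F)F)ccc2[nH]1`, 100000 nM

In an ADME assay on MT4 cells (Homo sapiens) for cytotoxicity, read by MTT assay, with a stated time of 96 h (on this read-out lower numbers stand for higher toxicity in this test and higher numbers for lower toxicity in this test), compound 1 gives 3000 nM, the lowest of the two numbers shown, so on this read-out it is the more toxic of the pair. Going by the values given here, its only neighbour is compound 2, whose number in this assay is well beyond the scatter above it, and the two structures differ in more than one place, so that gap says nothing about any single change. Compound 3, `COc1ccc(-c2nc3cc(Cl)c(Cl)cc3[nH]2)c([N+](=O)[O-])c1`, has not yet been measured. It differs from compound 1 as follows: nitro in place of amino on an aromatic carbon. Among the compounds with values here, no pair of measured compounds shows what this change does in this assay, so the size of the step is open. The account expects the step of a 1.7-fold higher number from compound 1 to compound 3 (0.22 log units; within the scatter) to be small, close to the scatter, with no firm direction. For compound 3 the estimate in this assay is 5000 nM, within 1000 nM to 30000 nM.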

Compound 3, half-maximal cytotoxic concentration: 2000 nM
The estimate for compound 3 lay 2.5-fold (0.40 log units) above the measured number; low and high end bracket the measured number.
By their numbers in this assay, from the lowest: compounds 3 and 1 (each within the scatter of the next); then compound 2.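

In this assay, going by these compounds alone, nitro in place of amino on the aromatic carbon ortho to a large group gives a 1.5-fold lower number from compound 1 to compound 3 (0.18 log units; within the scatter) and is the first single-place comparison available. It shows that, on this core, this read-out does not separate the two groups at this position, even though 1 hydrogen-bond donor leaves with the amino group and the nitro group brings 0 hydrogen-bond donors. No measurement shown here accounts for this outcome.

Going by these compounds, whether other groups at this position, such as a carboxylic acid or a dimethylamine, would also stay within the scatter of compound 1 remains open. Also open, on these data alone, is whether the same exchange would give so small a step on a different core, since compound 2 differs from compound 1 in more than one place.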